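From 4-nitrophenyl to 3-amino-4-methoxyphenyl

The source may report more compounds than this note shows. Statements on the series, on what has been measured and on what is new or still open speak of the compounds shown alone.

Measured so far in a functional assay on K-562R cells (Homo sapiens) for cytotoxicity, read by MTT assay, with a stated time of 48 h (a lower number here means a stronger inhibitor, a higher number a weaker inhibitor), as follows
- Compound 1 (`COc1ccc(-c2cn(C(=O)Nc3cc(OC)c(OC)c(OC)c3)c(=O)n2-c2cc(OC)c(OC)c(OC)c2)cc1OC`) gives > 50000 nM as a limit, not a number
- Compound 2 (`COc1cc(-n2c(-c3ccc([N+](=O)[O-])cc3)cn(C(C)=O)c2=O)cc(OC)c1OC`) gives 49600 nM as a number

Among the measured compounds shown here, compound 2 holds the only true number so far, at 49600 nM in this assay with nothing numeric to rank it against. For compound 1 the result > 50000 nM is a limit of the test.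

Compound 3 (`COc1ccc(-c2cn(C(C)=O)c(=O)n2-c2cc(OC)c(OC)c(OC)c2)cc1N`) keeps the acetyl group and the shared core of compound 2. It has 3-amino-4-methoxyphenyl in place of 4-nitrophenyl on an aromatic carbon of the five-membered aromatic ring with 2 nitrogen (3-amino-4-methoxyphenyl in place of 4-nitrophenyl on an aromatic carbon).

For the measured compounds named here, no two measured compounds differ in just one place, so no measured step can guide this change, and any forecast stays loose. Compound 2 at 49600 nM leaves little numeric room for a weaker result, so a sizeable move toward a stronger inhibitor is expected in this assay rather than none. Compound 3 is estimated at 2000 nM with an expected range from 50 nM to 45000 nM in this forecast. That estimate means an expected change a 25-fold lower number from compound 2 to compound 3 (1.39 log units; beyond the scatter) toward stronger inhibition.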

Compound 3, half-maximal inhibitory concentration: 49300 nM
Estimate against measurement, compound 3: 25-fold (1.39 log units) below, and the stated range ends below it.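

At this aromatic carbon of the five-membered aromatic ring with 2 nitrogen, putting 3-amino-4-methoxyphenyl in place of 4-nitrophenyl gives, in this assay, a 1.0-fold lower number from compound 2 to compound 3 (0.00 log units; within the scatter). Among the compounds shown here, this is the first measured step, and it shows that these two substituted phenyl groups, which carry different substituents but the same count of heavy atoms, cannot be told apart in this assay. The step has limited reach because both numbers lie close to the top of what the test reports, leaving little room to see a further loss of inhibition: the limit of > 50000 nM in this assay, at which 1 of the 3 values shown sits.

The compounds shown leave open whether any group at this aromatic carbon, such as a 3-hydroxy-4-methoxyphenyl or an unsubstituted phenyl, can give a clearly stronger result in this assay. They also leave open whether a longer chain such as propanoyl, in place of the acetyl group, would give a number clearly apart from those of compound 2 and compound 3.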